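Deoxyuridine series: oxime replaced by methylsulfonylmethyl

The source may hold more compounds than are shown below. What is called first, only, known or untested is meant among the compounds shown, and "the series" means these compounds.

Working notes on the series. In an ADME assay on L1210/0 cells (Mus musculus) for cytotoxicity, with a stated time of 48 h (on this read-out lower numbers stand for stronger inhibition and higher numbers for weaker inhibition), compound 1 `O=c1[nH]c(=O)n([C@H]2C[C@H](O)[C@@H](CO)O2)cc1/C=N/O` gives 15500 nM. Compound 2 `Nc1ncnc2c1ncn2C1CC(O)C(/C=N/O)O1` gives 17400 nM in this assay, a number within the scatter of that of compound 1, so the two cannot be separated. For compound 3 `Nc1ncnc2c1ncn2[C@@H]1C[C@@H]2COC[C@H]2[C@H]1CO` this assay reports only a limit, > 200000 nM; this is the limit of > 200000 nM in this assay, at which 1 of the 3 values shown sits. Among the numbers shown, compound 1 and compound 2 therefore stand together, and the third entry is a limit rather than a number.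

Compound 4 `CS(=O)(=O)Cc1cn([C@H]2C[C@H](O)[C@@H](CO)O2)c(=O)[nH]c1=O` has not yet been measured in this assay. It differs from compound 1 in one place: a group of 5 heavy atoms (2 carbon, 2 oxygen, 1 sulfur; no ring) in place of a group of 3 heavy atoms (1 carbon, 1 nitrogen, 1 oxygen; no ring), on an aromatic carbon. Going by the values given here, no step between measured compounds bears on this kind of change, so the direction cannot be read from the series itself. The expectation for the step in this assay is a moderate move toward a higher number, a 2.6-fold higher number from compound 1 to compound 4 (0.41 log units; beyond the scatter), with wide uncertainty. Compound 4 is estimated at 40000 nM in this assay, between 8000 nM and 200000 nM.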

Compound 4, half-maximal inhibitory concentration: > 200000 nM
Compound 4: a limit, no number; the forecaster's own chance of this, stated with the estimate: 25%; at least 5.0-fold (0.69 log units) between middle value and limit.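

Exchanging the oxime of compound 1 for (methylsulfonyl)methyl on this aromatic carbon gives an at least 12-fold higher number from compound 1 to compound 4 (1.11 log units; beyond the scatter) in this assay, the only step shown at this position. Going by these compounds alone, the read-out at this carbon therefore depends on the group it carries, which the earlier compounds could not show, and this change goes clearly toward weaker inhibition. The entry for compound 4 is a limit and not a number, so the step has a lower bound but no measured size: the limit of > 200000 nM in this assay, at which 2 of the 4 values shown sit.

One step cannot tell whether the oxime is specifically favoured or the (methylsulfonyl)methyl group is specifically disfavoured. Also open, as far as these compounds go, is where an amine, a carboxylic acid, or a sulfide chain of the same length on this carbon would fall relative to compound 1.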